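Working notes on a weakly cytotoxic series

The source may hold more compounds than are shown below. What is called first, only, known or untested is meant among the compounds shown, and "the series" means these compounds.

Measured so far:
compound 1 `Fc1cccc(-c2nc(Nc3ccccc3)c3cc(F)ccc3n2)c1` 49700 nM
compound 2 `COc1ccc(Nc2nc(-c3cccc(F)c3)nc3ccc(F)cc23)cc1` 46800 nM

In a functional assay on COLO 205 cells (Homo sapiens) for cytotoxicity, read by MTT assay, with a stated time of 48 h (a lower number here means a stronger inhibitor, a higher number a weaker inhibitor), compound 1 gives 49700 nM and compound 2 gives 46800 nM. Compound 2 carries the smaller of the two numbers, but the only step shown, a 1.1-fold lower number from compound 1 to compound 2 (0.03 log units; within the scatter), lies within the scatter, so the two cannot be told apart. Compound 3 `COc1ccccc1Nc1nc(-c2cccc(F)c2)nc2ccc(F)cc12` differs from compound 2 by 2-methoxyphenyl in place of 4-methoxyphenyl on a nitrogen on an aromatic ring. For the measured compounds named here, no measured step covers this change; the single step on record concerns a methoxy added to hydrogen and is within the scatter. Compound 3 is therefore expected to stay at the level of compound 2, a 1.0-fold higher number from compound 2 to compound 3 (0.00 log units; within the scatter). The estimate for compound 3 is 47000 nM, range 20000 nM to 110000 nM.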

Compound 3, half-maximal inhibitory concentration: > 50000 nM
Compound 3: a limit, no number; the forecaster's own chance of this, stated with the estimate: 20%; middle value at least 1.0-fold (0.02 log units) from the limit.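

In this assay, 2-methoxyphenyl in place of 4-methoxyphenyl on a nitrogen on an aromatic ring gives an at least 1.0-fold higher number from compound 2 to compound 3 (0.02 log units; that floor lies within the scatter). Methoxy in place of hydrogen on an aromatic carbon gives a number no lower from compound 1 to compound 3 (the limit leaves the size open), a step that cannot be read. Compound 3 gives no number, only a limit of the assay: the limit of > 50000 nM in this assay, at which 1 of the 3 values shown sits.

As far as these compounds go, how far compound 3 lies past that limit remains open. Also open, from the compounds shown here alone, is whether an amine or a carboxylic acid in place of the methoxy would give a clearly lower number.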